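Adding a Second Methyl to the Ring of Compound 1

This account rests on a few compounds, and the source may have more. Where it says the series, first, only, none or still open, it means among the compounds named here.

Compound 1 `Cc1ccc(S(=O)(=O)N2C(C)C2CO[C@@H]2O[C@@H]3CO[C@H](c4ccccc4)O[C@@H]3[C@H](OCc3ccccc3)[C@H]2OCc2ccccc2)cc1` holds the highest of the two numbers in a functional assay on A549 cells (Homo sapiens) for cytotoxicity, read by MTT assay, with a stated time of 48 h (on this read-out higher numbers stand for weaker inhibition and lower numbers for stronger inhibition), where compound 1 gives 804000 nM. Its nearest neighbour is compound 2 `Cc1ccc(S(=O)(=O)N2CC2CO[C@@H]2O[C@@H]3CO[C@H](c4ccccc4)O[C@@H]3[C@H](OCc3ccccc3)[C@H]2OCc2ccccc2)cc1`, which in this assay gives 73000 nM; the step of an 11-fold lower number from compound 1 to compound 2 (1.04 log units; beyond the scatter) puts hydrogen in place of methyl on a saturated ring carbon. Compound 3 `Cc1ccc(S(=O)(=O)N2C(CO[C@@H]3O[C@@H]4CO[C@H](c5ccccc5)O[C@@H]4[C@H](OCc4ccccc4)[C@H]3OCc3ccccc3)C2(C)C)cc1` differs from compound 1 by methyl in place of hydrogen on a saturated ring carbon. Within the data shown here, the only step that bears on this change runs the other way, so the added methyl is expected to raise the number or leave it within the scatter. Compound 3 is therefore expected to give about 1500000 nM, between 400000 nM and 6000000 nM. The expected step is a 1.9-fold higher number from compound 1 to compound 3 (0.27 log units; within the scatter).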

Compound 3, half-maximal inhibitory concentration: > 1000000 nM
Compound 3: only a limit was reported; the forecaster's own chance of this, stated with the estimate: 40%; the middle value does not contradict the limit.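

For compound 3 the reading in this assay is a limit and not a number: the limit of > 1000000 nM in this assay, at which 1 of the 3 values shown sits. Methyl in place of hydrogen on this saturated ring carbon, next to the ring nitrogen, gives an at least 1.2-fold higher number from compound 1 to compound 3 (0.09 log units; that floor lies within the scatter), so the limit does not separate compound 3 from compound 1 beyond the scatter. It does show that this added methyl brought no lower number, though the true size of the step cannot be told. On these data alone, how an amine or a carboxylic acid on this ring carbon would read remains open.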